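Swapping the Amine on a Dithiocarbamate Benzamide

The source may report more compounds than this note shows. Statements on the series, on what has been measured and on what is new or still open speak of the compounds shown alone.

Compound 1, `COc1ccc(N2CCN(C(=S)SCc3ccc(C(=O)Nc4ccccc4N)cc3)CC2)cc1`: 28.1%
Compound 2, `Nc1ccccc1NC(=O)c1ccc(CSC(=S)N2CCCc3ccccc32)cc1`: 26.5%

In a functional assay on A-375 cells (Homo sapiens) for antiproliferative activity, read by CCK-8 assay, with a stated time of 72 h, tested at 2 uM (a higher number here means a stronger effect of the compound at the concentration tested, a lower number a weaker effect), compound 1 gives 28.1% and compound 2 gives 26.5%. Compound 2 sits closest to compound 1, the gap between them being within the usual scatter, so the two cannot be told apart.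

Compound 3, `CCN(Cc1ccncc1)C(=S)SCc1ccc(C(=O)Nc2ccccc2N)cc1`, is not yet measured. It differs from compound 2 in one place: ethyl((pyridin-4-yl)methyl)amino in place of 1,2,3,4-tetrahydroquinolin-1-yl on a thiocarbonyl carbon. Among the measured compounds shown here, no measured pair shows a step of this kind, so its direction is open; compound 3 is expected to shift by a number 1.5 percentage points lower from compound 2 to compound 3 (within the scatter), a small step, likely not beyond the scatter. Compound 3 is therefore estimated at 25%, within 10% to 45%.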

Compound 3, a percentage reported as inhibition, at one concentration (the size of the read-out at that concentration, not a potency): 67.2%
Compound 3: middle estimate off by 42.2 percentage points, on the low side; measured number above the stated range.
By their numbers in this assay, from the lowest: compounds 2 and 1 (each within the scatter of the next); then compound 3.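

Swapping in ethyl((pyridin-4-yl)methyl)amino for 1,2,3,4-tetrahydroquinolin-1-yl brings a number 40.7 percentage points higher from compound 2 to compound 3 (beyond the scatter) in this assay, so the group on the thiocarbonyl carbon can move this read-out strongly. Both groups count 10 heavy atoms, so that count does not separate them. Nothing measured here gives a reason for the step.

The swap replaces the whole group at once, so the part that matters cannot be singled out. From the compounds shown here alone, whether the effect would survive with benzyl in place of (pyridin-4-yl)methyl, or with propyl in place of ethyl, remains open.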